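The source may hold more compounds than are shown below. What is called first, only, known or untested is meant among the compounds shown, and "the series" means these compounds.

Measured compounds:
compound 1, `C=C1CC[C@@H]2C(C)(C)[C@@H](Br)CC[C@]2(C)[C@@H]1Cc1cc(O)c(C=O)cc1O` — 5000 nM
compound 2, `C=C1CC[C@@H]2C(C)(C)[C@@H](Br)CC[C@]2(C)[C@H]1Cc1cc(O)c(C=O)cc1O` — 4000 nM

In an ADME assay on MT2 cells (Homo sapiens) for cytotoxicity, read by XTT assay (on this read-out lower numbers stand for higher toxicity in this test and higher numbers for lower toxicity in this test), compound 2 gives 4000 nM. Among the compounds with values here, the only other number here belongs to compound 1, which in this assay gives 5000 nM; the step of a 1.3-fold lower number from compound 1 to compound 2 (0.10 log units; within the scatter) separates the two, and it is within the scatter, so the two values cannot be told apart.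

Compound 3, `C=C1CC[C@H]2C(C)(C)[C@@H](Br)CC[C@]2(C)[C@H]1Cc1cc(O)c(C=O)cc1O`, has not yet been measured. Compared with compound 2 the change is this: the two compounds have the same atoms and bonds and differ only in configuration as drawn: 1 of 4 stereo elements differ; a stereocentre at a saturated ring carbon is drawn S in compound 2 and R in compound 3. Within the data shown here, the one measured step that bears on such a change is a 1.3-fold lower number from compound 1 to compound 2 (0.10 log units; within the scatter), which rests on the fact that compounds 1 and 2 differ only in the configuration as drawn and was itself within the scatter. On that basis no step beyond the scatter is expected in this assay from compound 2 to compound 3, in either direction.

Compound 3 is therefore estimated to give 4500 nM in this assay, with a range from 2000 nM to 10000 nM. This estimate means an expected step of a 1.1-fold higher number from compound 2 to compound 3 (0.05 log units; within the scatter), a movement that would remain inside the usual scatter.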

Compound 3, half-maximal cytotoxic concentration: 2000 nM
Estimate against measurement, compound 3: 2.3-fold (0.35 log units) above; measured number inside the range.
By their numbers in this assay, from the lowest: compounds 3, 2 and 1 (each within the scatter of the next, the first and the last beyond it).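

In this assay, the change at the second saturated ring carbon gives a 2.0-fold lower number from compound 2 to compound 3 (0.30 log units; within the scatter), so neither stereocentre taken alone yields a step beyond the scatter, just as the earlier change between compound 1 and compound 2 did not. Taken together, however, the two changes give a 2.5-fold lower number from compound 1 to compound 3 (0.40 log units; beyond the scatter), the first step in this set to lie beyond the scatter, which shows that configuration at these two carbons can register in this read-out, though only modestly. The atoms and bonds stay the same, so this gap can only be attributed to stereochemistry, because of the following: the fact that compounds 1 and 3 differ only in the configuration as drawn

The compounds shown do not tell whether the two stereocentres act independently or whether the gap simply reflects two small shifts added together, since a single step within the scatter cannot be sized reliably. They also leave open how far the read-out depends on the substituents rather than on the configuration, for instance whether a chlorine in place of the bromine or a carboxylic acid in place of the aldehyde would move it more than these changes of configuration do.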